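A few compounds are considered here, and "the series" means these few. Any claim that something is new, unique, unknown or untested is made for them only; others in the source may bear on it.

Measured so far in a functional assay on MDA-MB-436 cells (Homo sapiens) for antiproliferative activity, read by MTT assay, with a stated time of 48 h; on this read-out lower numbers stand for stronger inhibition and higher numbers for weaker inhibition:

compound 1, `C=CS(=O)(=O)N1CCN(c2ncnc3sc(-c4ccc(OC)nc4)cc23)CC1`: 11900 nM
compound 2, `C=CS(=O)(=O)N1CCN(c2nc(OC[C@H]3CCCN3C)nc3sc(-c4ccc(OC)nc4)cc23)CC1`: 4980 nM
compound 3, `C=CS(=O)(=O)N1CCN(c2nc(OC[C@H]3CCCN3C)nc3sc(-c4ccc(N5CCN(C)CC5)cc4)cc23)[C@@H](C)C1`: 1920 nM

Going by the values given here, the single counted change in the set is hydrogen in place of (1-methylpyrrolidin-2-yl)methoxy on an aromatic carbon, which gave a 2.4-fold higher number from compound 2 to compound 1 (0.38 log units; beyond the scatter). Compound 3 carries a different core; the difference between its core and that of compound 2 is not broken down here. Compound 4, `C=CS(=O)(=O)N1CCN(c2ncnc3sc(-c4ccc(N5CCN(C)CC5)cc4)cc23)[C@@H](C)C1`, is compound 3 after the same kind of change, (hydrogen in place of (1-methylpyrrolidin-2-yl)methoxy on an aromatic carbon); the surroundings differ only in that the place is meta to a 2-methyl-4-(vinylsulfonyl)piperazin-1-yl group rather than meta to a 4-(vinylsulfonyl)piperazin-1-yl group. Among the compounds with values here, with one earlier instance as the only guide, the expected step is a 2.4-fold higher number from compound 3 to compound 4 (0.38 log units; beyond the scatter), resting on a 2.4-fold higher number from compound 2 to compound 1 (0.38 log units; beyond the scatter). Compound 4 is therefore estimated at 4600 nM, expected within 2000 nM to 11000 nM.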

Compound 4, half-maximal inhibitory concentration: 6920 nM
Estimate against measurement, compound 4: 1.5-fold (0.18 log units) below; the range from low to high includes it.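

In this assay, hydrogen in place of (1-methylpyrrolidin-2-yl)methoxy on an aromatic carbon gives a 3.6-fold higher number from compound 3 to compound 4 (0.56 log units; beyond the scatter). Set beside the earlier step, the change carries from one core to the other with no difference that can be told apart: the same change on two cores in this assay, a 2.4-fold higher number (0.38 log units; beyond the scatter) from compound 2 to compound 1 and a 3.6-fold higher number (0.56 log units; beyond the scatter) from compound 3 to compound 4, 1.5-fold (0.18 log units) apart, within the scatter of two such steps. Two pairs do not show that this holds on other cores in the series, and they do not show which part of the group accounts for the step.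

Still open, as far as these compounds go, is what a plain methoxy, an open-chain dimethylaminoethoxy group or a primary amine would give at the same place between two ring nitrogen atoms. From the compounds shown here alone, the opposite stereocentre of the (1-methylpyrrolidin-2-yl)methoxy group also remains open.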